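Hydroxy in place of hydrogen on the cinnamamide aryl ring

The source may hold more compounds than are shown below. What is called first, only, known or untested is meant among the compounds shown, and "the series" means these compounds.

Measured compounds:
compound 1 `CC(C)(C)c1ccc(/C(=C/C(=O)Nc2ccc3c(c2)OCCO3)Cc2ccccc2)cc1`: 110 nM
compound 2 `CC(C)(C)c1ccc(/C=C/C(=O)Nc2ccc3c(c2)NC(=O)CC3)cc1`: 71 nM
compound 3 `O=C(/C=C/c1ccccc1)Nc1ccc2c(c1)OCCO2`: > 4000 nM

In a functional assay on CHO cells for inhibition of transient receptor potential cation channel subfamily V member 1 (Homo sapiens) (on this read-out lower numbers stand for stronger inhibition and higher numbers for weaker inhibition), compound 1 gives 110 nM and compound 2 gives 71 nM. Compound 3 stands apart from both: in this assay compound 3 reports only the limit > 4000 nM, a limit of the assay and not a number. That limit is the weakest point among the three values shown (the limit of > 4000 nM in this assay, at which 1 of the 3 values shown sits). Both compounds with a number carry a tert-butyl group; compound 3 carries no substituent on the corresponding ring.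

Compound 4 `O=C(/C=C/c1ccc(O)cc1)Nc1ccc2c(c1)OCCO2` has not yet been measured. It differs from compound 3 by hydroxy in place of hydrogen on an aromatic carbon. Within the data shown here, no step between measured compounds is known, so the size of this change in this assay cannot be read from the series. The step from compound 3 to compound 4 is expected to be small, a step that the limit leaves unreadable from compound 3 to compound 4, most likely none beyond the scatter, with compound 4 staying weak and a fair chance of another limit. Compound 4 is expected at 6000 nM, within a range of 1500 nM to 20000 nM.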

Compound 4, half-maximal inhibitory concentration: > 4000 nM
Compound 4 ended at the assay's limit; the forecaster's own chance of this, stated with the estimate: 55%; the middle value does not contradict the limit.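

In this assay, among these compounds, compound 3 and compound 4 both rest at a limit of the assay and not at a number, so no step between them can be read: the limit of > 4000 nM in this assay, at which 2 of the 4 values shown sit. The compounds shown leave open whether hydroxy in place of hydrogen on the aromatic ring changes the read-out at all, in either direction.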